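Morpholine for Pyrrolidine on the Thiocarbonyl Carbon

This account rests on a few compounds, and the source may have more. Where it says the series, first, only, none or still open, it means among the compounds named here.

Compound 1 `Cc1ccnc(/C(N)=N/NC(=S)N2CCCC2)c1`: 69%
Compound 2 `N/C(=N\NC(=S)N1CCN(c2ccccn2)CC1)c1ccc(F)cn1`: 49.3%
Compound 3 `Cc1cccc(/C(N)=N/NC(=S)N2CCCC2)n1`: 13.6%

In a functional assay on A-375 cells (Homo sapiens) for cytotoxicity, read by MTT assay, with a stated time of 72 h, tested at 1 uM (on this read-out higher numbers stand for more inhibition of growth at the one concentration tested and lower numbers for less inhibition of growth), compound 1 gives the highest of the three numbers. Compound 2 sits lower by a margin beyond the scatter, and compound 3 sits far lower still, also beyond the scatter. Compound 4 `Cc1ccnc(/C(N)=N/NC(=S)N2CCOCC2)c1` has not yet been measured. It differs from compound 1 in one place: morpholin-4-yl in place of pyrrolidin-1-yl on a thiocarbonyl carbon. Within the data shown here, no pair of measured compounds differs in just one place, so no measured step shows what such a change does here. A downward step beyond the scatter is nevertheless expected in this assay, estimated as a number 21 percentage points lower from compound 1 to compound 4 (beyond the scatter). Compound 4 is therefore expected to give about 48%, with a likely range from 25% to 70%.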

Compound 4, percent growth inhibition at one concentration: 43.2%
Compound 4: the middle estimate sits 4.8 percentage points above what was measured; measured number inside the range.
By their numbers in this assay, from the lowest: compound 3; then compounds 4 and 2 (each within the scatter of the next); then compound 1.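

In this assay, among these compounds, this is the first measured single-place step at the thiocarbonyl carbon: a number 25.8 percentage points lower from compound 1 to compound 4 (beyond the scatter). On this core, morpholin-4-yl therefore does not match pyrrolidin-1-yl, and the swap brings a six-membered ring and a hydrogen-bond acceptor together. Nothing available here explains the drop. The compounds shown leave open whether the ring size or the ring oxygen accounts for the step, as both change at once. Piperidin-1-yl on the same carbon, a six-membered ring without the oxygen, would separate the two.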